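Trimming the amide aryl: from compound 2 to compound 3

The source may hold more compounds than are shown below. What is called first, only, known or untested is meant among the compounds shown, and "the series" means these compounds.

Compound 1, `COc1ccc2nc(C)cc(OCC(=O)Nc3cccc(C)c3)c2c1`: 39800 nM
Compound 2, `COc1ccc2nc(C)cc(OCC(=O)Nc3cc(C)c(F)c(C)c3)c2c1`: > 100000 nM (a limit)

Of the compounds shown here, two have been measured in a toxicity assay on HepG2 cells (Homo sapiens) for inhibition, read by CellTiter-Glo, with a stated time of 48 h; a higher number here means a weaker inhibitor, a lower number a stronger inhibitor. In this assay compound 1 gives 39800 nM. Compound 2 returns only a limit of the assay, > 100000 nM. Compound 2 thus stands at the weak end of what the assay can report, as shown by the limit of > 100000 nM in this assay, at which 1 of the 2 values shown sits. Among the compounds with values here, the one measured step, an at least 2.5-fold higher number from compound 1 to compound 2 (0.40 log units; beyond the scatter), is the only guide available. Compound 3, `COc1ccc2nc(C)cc(OCC(=O)Nc3ccc(F)cc3)c2c1`, differs from compound 2 by 4-fluorophenyl in place of 4-fluoro-3,5-dimethylphenyl on an amide-type nitrogen. Within the data shown here, this change keeps the fluorine and removes the two methyl groups; no measured step isolates those methyl groups, and the expected size of the step is uncertain. The expectation is a step near nothing, or a small move toward the stronger side, an at least 1.1-fold lower number from compound 2 to compound 3 (0.04 log units; that floor lies within the scatter). Compound 3 is expected to give about 90000 nM, within a range from 35000 nM to 250000 nM, with a fair chance that only a limit is again reported.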

Compound 3, half-maximal inhibitory concentration: 63100 nM
Compound 3: middle estimate off by 1.4-fold (0.15 log units), on the high side; measured number inside the range.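

Compound 3 gives a measured number in this assay, so the 4-fluorophenyl group can be compared directly with 3-methylphenyl on the amide-type nitrogen: the comparison gives a 1.6-fold higher number from compound 1 to compound 3 (0.20 log units; within the scatter), which does not separate these two groups. Removing the two methyl groups while keeping the fluorine gives an at least 1.5-fold lower number from compound 2 to compound 3 (0.19 log units; that floor lies within the scatter). The true size of that step cannot be read because compound 2 is known only as a limit: the limit of > 100000 nM in this assay, at which 1 of the 3 values shown sits.

The compounds shown leave open what the fluorine contributes on its own and what a single methyl group would do on the 4-fluorophenyl ring. They also leave open how an amine or a carboxylic acid on this aromatic ring would read in this assay.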